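Trading a methyl ester for a free acid on a thiophene-like core

The compounds below may be only part of what the source reports. "The series", "measured", "known", "first", "only" and "open" are said of these compounds alone.

Going by the values given here, compound 1, with the structure `COC(=O)c1c(Nc2ccc(F)cc2)sc(C(=O)c2ccc(OC)cc2)c1C`, is the only member of this small set that returns a number in a functional assay, with a stated time of 150 min, tested at 15 ug/mL; on this read-out lower numbers stand for a weaker effect and higher numbers for a stronger effect at the one concentration tested: compound 1 gives 15.2%. Two close relatives return no number at all. Compound 2, `COC(=O)c1c(Nc2ccc(Cl)cc2)sc(C(=O)c2ccc(OC)cc2)c1C`, is reported in this assay as "not active" (no number reported), and compound 3, `COC(=O)c1c(Nc2ccc(F)cc2)sc(C(=O)c2ccc(C)cc2)c1C`, is reported as "not active" (no number reported). Among the compounds with values here, compound 1 therefore stands alone with a measured, though modest, read-out, and no pair of measured compounds differing in a single place is available to show how large a one-step change tends to be here.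

Compound 4, `COc1ccc(C(=O)c2sc(Nc3ccc(F)cc3)c(C(=O)O)c2C)cc1`, is the next compound to be tested. It differs from compound 1 in one place: hydrogen in place of methyl on an oxygen next to a carbonyl group, so that methoxycarbonyl becomes carboxy. Within the data shown here, with no comparable step available, the expected change is none beyond the usual scatter, which means the step from compound 1 to compound 4 is estimated at a number 3.2 percentage points lower from compound 1 to compound 4 (within the scatter). Compound 4 is accordingly expected to give about 12%, within a range from 0% to 30%.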

Compound 4, a percentage reported as activity, at one concentration (the size of the read-out at that concentration, not a potency): 1.98%
The estimate for compound 4 lay 10 percentage points above the measured number; low and high end bracket the measured number.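

In this assay, going by these compounds alone, putting hydrogen in place of methyl on an oxygen next to a carbonyl group gives a number 13.2 percentage points lower from compound 1 to compound 4 (beyond the scatter), the first step in this set with a number at both ends. It shows that this position is not indifferent to the change: with the core otherwise unchanged, turning methoxycarbonyl into carboxy leaves a smaller read-out at the one concentration tested. Nothing measured here accounts for the drop.

From the compounds shown here alone, only methyl and hydrogen have been compared on this oxygen, so it remains open whether a longer chain such as an ethyl ester, or a primary amide in place of the ester, would hold or lose the read-out. Going by these compounds, compound 2 and compound 3 carry no number, so how the same change would behave on those two stays open as well.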